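Amide-for-urea step on the 3-(trifluoromethyl)phenyl arm

This account rests on a few compounds, and the source may have more. Where it says the series, first, only, none or still open, it means among the compounds named here.

Within this set, compound 3 `O=C(Nc1ccc(-n2ccc3c(NC(=O)c4ccccc4)ncnc32)cc1)Nc1cccc(C(F)(F)F)c1` holds the highest number: in a functional assay on A375P cells (Homo sapiens) for antiproliferative activity, read by MTT assay, with a stated time of 24 h (on this read-out higher numbers stand for weaker inhibition and lower numbers for stronger inhibition), compound 3 gives 9500 nM, while compound 1 `O=C(Nc1ccc(-n2ccc3c(NC(=O)c4ccccc4)ncnc32)cc1)Nc1ccc(Cl)c(C(F)(F)F)c1` gives 4600 nM and compound 2 `O=C(Nc1ccc(-n2ccc3c(NC(=O)c4ccccc4)ncnc32)cc1)c1ccc(Cl)c(C(F)(F)F)c1` gives 2300 nM. Compound 4 `O=C(Nc1ccc(-n2ccc3c(NC(=O)c4ccccc4)ncnc32)cc1)c1cccc(C(F)(F)F)c1` differs from compound 3 by 3-(trifluoromethyl)phenyl in place of (3-(trifluoromethyl)phenyl)amino on a carbonyl carbon. The same exchange on a carbonyl carbon is already seen once, as a 2.0-fold lower number from compound 1 to compound 2 (0.30 log units; within the scatter), which does not exceed the scatter. The related steps of a 2.1-fold higher number from compound 1 to compound 3 (0.31 log units; beyond the scatter) and a 4.1-fold higher number from compound 2 to compound 3 (0.62 log units; beyond the scatter) concern the chloro instead and bear only indirectly. A small lowering of the number, or none beyond the scatter, is therefore expected in this assay, and the expected step is a 1.7-fold lower number from compound 3 to compound 4 (0.24 log units; within the scatter). Compound 4 is estimated at 5500 nM, with a range of 2500 nM to 12000 nM.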

Compound 4, half-maximal inhibitory concentration: 4700 nM
For compound 4 the middle estimate is 1.2-fold (0.07 log units) above the measured one, and the stated range covers the measured number.
By their numbers in this assay, from the lowest: compounds 2, 1 and 4 (each within the scatter of the next, the first and the last beyond it); then compound 3.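

In this assay, the amide-for-urea exchange on the 3-(trifluoromethyl)phenyl arm gives a 2.0-fold lower number from compound 3 to compound 4 (0.31 log units; beyond the scatter), so on this arm the step passes the scatter, unlike the step on the chloro-bearing pair. Removing the chloro from the amide gives a 2.0-fold higher number from compound 2 to compound 4 (0.31 log units; beyond the scatter), and the chloro step now reads the same on urea and amide: the same change on two cores in this assay, a 2.1-fold higher number (0.31 log units; beyond the scatter) from compound 1 to compound 3 and a 2.0-fold higher number (0.31 log units; beyond the scatter) from compound 2 to compound 4, 1.0-fold (0.00 log units) apart, within the scatter of two such steps With both places changed, the step is a 1.0-fold higher number from compound 1 to compound 4 (0.01 log units; within the scatter).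

From the compounds shown here alone, whether a bromo or a methoxy in place of chloro follows the same step stays open, as does the effect of a longer chain between the carbonyl carbon and the aromatic ring.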